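Amide to urea on a shared core: what to expect

This account rests on a few compounds, and the source may have more. Where it says the series, first, only, none or still open, it means among the compounds named here.

Three compounds share one core and differ only in the aryl group attached to the carbonyl. In an assay on isolated protein for inhibition of serine/threonine-protein kinase PAK 1 (Homo sapiens), read by ADP-Glo, with a stated time of 40 min (a lower number here means a stronger inhibitor, a higher number a weaker inhibitor), compound 1 `O=C(NC1CCN(c2ncnc3[nH]ncc23)CC1)c1ccc(F)cc1` gives 4540 nM, compound 2 `O=C(NC1CCN(c2ncnc3[nH]ncc23)CC1)c1ccc(C(F)(F)F)cc1` gives 5740 nM, and compound 3 `O=C(NC1CCN(c2ncnc3[nH]ncc23)CC1)c1cccc(Cl)c1Cl` gives 4170 nM. Compound 3 has the lowest of the three numbers, but the step of a 1.1-fold lower number from compound 1 to compound 3 (0.04 log units; within the scatter) is within the scatter, and its gap to compound 2 is also within the scatter, so none of the three can be called stronger than another.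

Compound 4 `O=C(Nc1ccc(Cl)c(Cl)c1)NC1CCN(c2ncnc3[nH]ncc23)CC1` is not yet measured. It differs from compound 3 by (3,4-dichlorophenyl)amino in place of 2,3-dichlorophenyl on a carbonyl carbon, so the amide becomes a urea and the two chlorines move to other places on the ring. For the measured compounds named here, no measured pair shows an amide turning into a urea. The steps that exist, a 1.3-fold higher number from compound 1 to compound 2 (0.10 log units; within the scatter) and a 1.1-fold lower number from compound 1 to compound 3 (0.04 log units; within the scatter), only show that swapping one aryl group for another on this core has not moved the number beyond the scatter. On that basis the step of a 1.1-fold higher number from compound 3 to compound 4 (0.03 log units; within the scatter) is expected to stay within the scatter, with no direction favoured. Compound 4 is therefore estimated at 4500 nM, in a range from 1500 nM to 13000 nM.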

Compound 4, half-maximal inhibitory concentration: 2290 nM
Compound 4: the middle estimate sits 2.0-fold (0.29 log units) above what was measured; measured number inside the range.
By their numbers in this assay, from the lowest: compounds 4, 3, 1 and 2 (each within the scatter of the next, the first and the last beyond it).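

In this assay, the first urea in this set gives a 1.8-fold lower number from compound 3 to compound 4 (0.26 log units; within the scatter), and against the fluorinated amide it gives a 2.0-fold lower number from compound 1 to compound 4 (0.30 log units; within the scatter). For the compounds shown here, neither step lies beyond the scatter, so this carbonyl carbon can carry (3,4-dichlorophenyl)amino, with its added nitrogen and hydrogen-bond donor, and the number stays within the scatter of both amides, yet the ranking now holds one pair that is separated beyond the scatter: compound 2 at 5740 nM and compound 4 at 2290 nM, the first sign that a change at this position can move the number measurably. No measurement available here explains why the values fall as they do.

The step from compound 3 to compound 4 changes the link to the ring and the places of the chlorines at once, so the compounds shown cannot say how much each contributes, and a urea carrying 2,3-dichlorophenyl would be needed to separate them. Also open, from the compounds shown here alone, is how this position responds to quite different groups, such as an amine or a carboxylic acid on the aromatic ring, or a longer chain in place of the ring.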